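Sigma-1 displacement: phenoxy replacing benzyl on the chain

The compounds below may be only part of what the source reports. "The series", "measured", "known", "first", "only" and "open" are said of these compounds alone.

Measured so far:
compound 1 `O=C(c1ccccc1)N1CCC(N2CCc3ccccc3C(O)C2)CC1` — 800 nM
compound 2 `O=[N+]([O-])c1ccc2c(c1)C(O)CN(CCCCCc1ccccc1)CC2` — 100 nM

Compound 2 `O=[N+]([O-])c1ccc2c(c1)C(O)CN(CCCCCc1ccccc1)CC2` gives 100 nM in an ADME assay on cell membranes for displacement of a labelled ligand from Sigma non-opioid intracellular receptor 1 (Cavia porcellus), read by scintillation counting, with a stated time of 120 min (a higher number here means a weaker inhibitor, a lower number a stronger inhibitor), the lowest of the two numbers in hand. Compound 1 `O=C(c1ccccc1)N1CCC(N2CCc3ccccc3C(O)C2)CC1` gives 800 nM in this assay, and the gap between the two lies beyond the scatter; the two structures differ in several places at once, so no single step can be read from them.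

Compound 3 `O=[N+]([O-])c1ccc2c(c1)C(O)CN(CCCCOc1ccccc1)CC2` is not yet measured in this assay. Its change from compound 2 is phenoxy in place of benzyl on a saturated chain carbon, four bonds along the chain from an amine nitrogen in a ring. The chain length in heavy atoms stays the same, and only one hydrogen-bond acceptor enters. Within the data shown here, no measured pair shows this particular change, so the size of the step is open; the expectation is a step of no size beyond the scatter, in either direction, as given by a 1.2-fold higher number from compound 2 to compound 3 (0.08 log units; within the scatter). Compound 3 is therefore estimated at 120 nM in this assay, with a range from 40 nM to 400 nM.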

Compound 3, inhibition constant: 1500 nM
Estimate against measurement, compound 3: 13-fold (1.10 log units) below; measured number outside the range, above it.
By their numbers in this assay, from the lowest: compound 2; then compounds 1 and 3 (each within the scatter of the next).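

In this assay, phenoxy and benzyl are not interchangeable on this saturated chain carbon, four bonds along the chain from the amine nitrogen in the ring: phenoxy in place of benzyl gives a 15-fold higher number from compound 2 to compound 3 (1.18 log units; beyond the scatter). The heavy-atom count and the six-membered aromatic ring of carbon stay the same, so the counted differences are one oxygen for one carbon and one added hydrogen-bond acceptor, and this single pair shows that the chain position responds strongly to that swap. No measurement here bears on what lies behind the size of the step.

The compounds shown leave open whether the step belongs to the oxygen specifically, which a thioether or a secondary amine in the same place would help to settle, and whether a longer chain ending in phenoxy would give back any of the lost strength of inhibition. Among these compounds, it is also open whether the step carries over to compounds without the nitro group on the shared core, since only one pair speaks to this change.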